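From Oxazole to Phenyl: What to Expect for Compound 3

The source may report more compounds than this note shows. Statements on the series, on what has been measured and on what is new or still open speak of the compounds shown alone.

Of the compounds shown here, two sharing one core have so far been measured in an assay on HEK293 cells for inhibition of N-acylethanolamine-hydrolyzing acid amidase (Homo sapiens), read by fluorescence, with stated times of 10 min and 50 min; a lower number here means a stronger inhibitor, a higher number a weaker inhibitor. Compound 1 `CCCCc1ccc(COC(=O)N[C@H]2CNC2=O)cc1` carries a butyl group and gives 23 nM. Compound 2 `O=C(N[C@H]1CNC1=O)OCc1ccc(-c2cocn2)cc1` carries 1,3-oxazol-4-yl in its place and gives 1880 nM. That single exchange produced an 82-fold higher number from compound 1 to compound 2 (1.91 log units; beyond the scatter). Compound 2 therefore stands at the higher of the two numbers and is the weaker inhibitor of the pair.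

Compound 3 `O=C(N[C@H]1CNC1=O)OCc1ccc(-c2ccccc2)cc1` has not yet been measured. It differs from compound 2 by phenyl in place of 1,3-oxazol-4-yl on an aromatic carbon. Among the measured compounds shown here, the only measured step bearing on this position is the exchange of butyl for the oxazole, and it was large. The entering phenyl, like the butyl of compound 1, carries no hydrogen-bond acceptors, while the leaving oxazole carries two, so the change is in part a return toward compound 1. For the measured compounds named here, the expected step is a 16-fold lower number from compound 2 to compound 3 (1.19 log units; beyond the scatter), a partial return rather than a full one, since no measured step involves phenyl itself. Compound 3 is thus estimated at 120 nM, with a range from 25 nM to 600 nM.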

Compound 3, half-maximal inhibitory concentration: 513 nM
Beside the measured number, compound 3's estimate is 4.3-fold (0.63 log units) below it; low and high end bracket the measured number.
By their numbers in this assay, from the lowest: compound 1; then compound 3; then compound 2.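

In this assay, phenyl in place of 1,3-oxazol-4-yl gives a 3.7-fold lower number from compound 2 to compound 3 (0.56 log units; beyond the scatter), which shows that the choice of aromatic ring at this place, para to a large group, changes the result and that compound 2 does not mark the level for every ring here. Phenyl does not bring back the level of butyl, however: there is a 22-fold higher number from compound 1 to compound 3 (1.35 log units; beyond the scatter), and this remaining step is the larger of the two, so two groups without hydrogen-bond acceptors can still lie far apart. Nothing measured here gives a reason for either step.

The compounds shown leave open how a longer chain such as hexyl, or a saturated ring such as cyclohexyl, would compare with butyl at this place. They also leave open whether a pyridine ring would fall nearer to compound 3 or to compound 2.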